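Adding bromo: an estimate from one number

The compounds below may be only part of what the source reports. "The series", "measured", "known", "first", "only" and "open" are said of these compounds alone.

- compound 1 `CN(CCCn1c(=O)oc2ccccc21)Cc1ccccc1`: > 100000 nM (a limit)
- compound 2 `CN(CCCn1c(=O)oc2ccc(Cl)cc21)Cc1ccccc1`: > 100000 nM (a limit)
- compound 3 `CN(CCCn1c(=O)sc2ccccc21)Cc1ccccc1`: 10000 nM

Among the measured compounds shown here, in an ADME assay on SH-SY5Y cells (Homo sapiens) for cytotoxicity, read by MTT assay, with a stated time of 72 h (on this read-out higher numbers stand for weaker inhibition and lower numbers for stronger inhibition), compound 3 gives 10000 nM, the only true number available. Compound 1 and compound 2 stand at the limit of > 100000 nM in this assay, at which 2 of the 3 values shown sit. Compound 4 `CN(CCCn1c(=O)sc2ccc(Br)cc21)Cc1ccccc1` carries bromo in place of hydrogen on an aromatic carbon of compound 3: bromo in place of hydrogen on an aromatic carbon. The closest measured change, chloro in place of hydrogen on an aromatic carbon, is a step that the two limits leave unreadable from compound 1 to compound 2, so it offers no size to carry over. No step beyond the usual scatter is therefore expected in this assay, in either direction, and the estimate rests on compound 3 at 10000 nM. This amounts to an expected no change at the digits printed from compound 3 to compound 4 (within the scatter). For compound 4 the estimated value is 10000 nM, with an expected range of 3000 nM to 40000 nM.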

Compound 4, half-maximal inhibitory concentration: 26500 nM
For compound 4 the middle estimate is 2.7-fold (0.42 log units) below the measured one; the range from low to high includes it.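

In this assay, bromo in place of hydrogen on this aromatic carbon gives a 2.7-fold higher number from compound 3 to compound 4 (0.42 log units; beyond the scatter), so this change has a readable size, and on this read-out it means weaker inhibition. The earlier chloro step cannot be read, because compound 1 and compound 2 both sit at a limit: the limit of > 100000 nM in this assay, at which 2 of the 4 values shown sit.

This is one step on one core, so it sets no trend. From the compounds shown here alone, whether chloro, methoxy or an amine at this carbon of compound 3 would move the number the same way stays open.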